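This account rests on a few compounds, and the source may have more. Where it says the series, first, only, none or still open, it means among the compounds named here.

Series notes, compound 3 to compound 4.

For the measured compounds named here, the three measured members share one core and differ only along the four-carbon chain that joins the two aryl ethers. Compound 1 `CCCc1c(OCCCCOc2ccc(-c3nn[nH]n3)cc2)ccc(C(C)=O)c1O` gives 348 nM in an assay on isolated protein for binding affinity to metabotropic glutamate receptor 2 (Homo sapiens), read by GTPgammaS binding; a lower number here means that less compound is needed, a higher number that more compound is needed for the effect. Compound 2 `CCCc1c(OC(C)CCCOc2ccc(-c3nn[nH]n3)cc2)ccc(C(C)=O)c1O` gives 918 nM, and compound 3 `CCCc1c(OCCCC(C)Oc2ccc(-c3nn[nH]n3)cc2)ccc(C(C)=O)c1O` gives 495 nM. Compound 3 thus stands second highest of the three numbers, yet its separation from compound 1 and from compound 2 lies within the scatter in both cases.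

Compound 4 `CCCc1c(OC(C)CCC(C)Oc2ccc(-c3nn[nH]n3)cc2)ccc(C(C)=O)c1O` is unmeasured. It differs from compound 3 by methyl in place of hydrogen on a saturated chain carbon bound to an oxygen on an aromatic ring and a saturated chain carbon. The two measured steps of the same kind on the parent both start from compound 1: a 2.6-fold higher number from compound 1 to compound 2 (0.42 log units; beyond the scatter), and a 1.4-fold higher number from compound 1 to compound 3 (0.15 log units; within the scatter). Compound 4 carries both methyls at once, so the change from compound 3 to compound 4 corresponds to the step from compound 1 to compound 2, which was beyond the scatter.

An upward step of about a 2.4-fold higher number from compound 3 to compound 4 (0.38 log units; beyond the scatter) is therefore expected in this assay for compound 4. The estimate for compound 4 is 1200 nM, with a range from 500 nM to 3000 nM.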

Compound 4, half-maximal effective concentration: 241 nM
For compound 4 the middle estimate is 5.0-fold (0.70 log units) above the measured one; the measured number lies below the stated range.
By their numbers in this assay, from the lowest: compounds 4, 1, 3 and 2 (each within the scatter of the next, the first and the last beyond it).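

In this assay, methyl in place of hydrogen on this saturated chain carbon gives a 2.1-fold lower number from compound 3 to compound 4 (0.31 log units; beyond the scatter), so the change lowers the number on the chain that already carries the other methyl, whereas it raises the number on the chain of compound 1: the same change on two cores in this assay, a 2.6-fold higher number (0.42 log units; beyond the scatter) from compound 1 to compound 2 and a 2.1-fold lower number (0.31 log units; beyond the scatter) from compound 3 to compound 4, 5.4-fold (0.73 log units) apart, beyond the scatter of two such steps

The other methyl of the pair also depends on its partner, giving a 3.8-fold lower number from compound 2 to compound 4 (0.58 log units; beyond the scatter) once the first methyl is present: the same change on two cores in this assay, a 1.4-fold higher number (0.15 log units; within the scatter) from compound 1 to compound 3 and a 3.8-fold lower number (0.58 log units; beyond the scatter) from compound 2 to compound 4, 5.4-fold (0.73 log units) apart, beyond the scatter of two such steps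

Across these four compounds the two methyls therefore do not add up, and a step read on one core does not carry over to the other.

As far as these compounds go, whether ethyl or fluorine on these carbons, or a longer chain joining the two aryl ethers, would show the same reversal stays open. The four values also give no reason for the reversal.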